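A few compounds are considered here, and "the series" means these few. Any claim that something is new, unique, unknown or untested is made for them only; others in the source may bear on it.

Measured so far in a functional assay on CHO-K1 cells for antagonist activity at melanin-concentrating hormone receptor 1 (Homo sapiens), read by inositol phosphate accumulation, with stated times of 10 min and 45 min; a lower number here means a stronger inhibitor, a higher number a weaker inhibitor:
compound 1 `Cc1nc(NCCNS(C)(=O)=O)nc2ccc(NC(=O)/C=C/c3ccc(OC(F)(F)F)cc3)cc12`, 142 nM
compound 2 `C/C(=C\C(=O)Nc1ccc2nc(N3CCC(O)CC3)nc(C)c2c1)c1ccc(Cl)cc1`, 227 nM

Compound 1 holds the lower of the two numbers, yet compound 2 lies within the scatter of it, so the two cannot be placed in order. Compound 3 `Cc1nc(N2CCC(N3CCNC3=O)CC2)nc2ccc(NC(=O)/C=C/c3ccc(OC(F)(F)F)cc3)cc12` has not yet been measured. It differs from compound 1 in one place: 4-(2-oxoimidazolidin-1-yl)piperidin-1-yl in place of (2-(methanesulfonamido)ethyl)amino on an aromatic carbon. Among the compounds with values here, no step between measured compounds is available to size such a change, so the expectation rests only on compounds 1 and 2, whose numbers sit within the scatter of each other. The step is expected to be small, at most within the scatter: a 1.1-fold higher number from compound 1 to compound 3 (0.05 log units; within the scatter). Compound 3 is estimated at 160 nM, within 45 nM to 550 nM.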

Compound 3, half-maximal inhibitory concentration: 31 nM
Beside the measured number, compound 3's estimate is 5.2-fold (0.71 log units) above it; measured number below the stated range.
By their numbers in this assay, from the lowest: compound 3; then compounds 1 and 2 (each within the scatter of the next).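

This position on the shared core, the aromatic carbon between two ring nitrogen atoms, is not indifferent to what it carries. In this assay, replacing (2-(methanesulfonamido)ethyl)amino, which has no ring, with 4-(2-oxoimidazolidin-1-yl)piperidin-1-yl, which has two non-aromatic rings, gives a 4.6-fold lower number from compound 1 to compound 3 (0.66 log units; beyond the scatter) and so a real, modest gain. No measurement here accounts for that gain.

One step cannot show whether the piperidine ring or the 2-oxoimidazolidin-1-yl ring matters more. As far as these compounds go, how a morpholine or an unsubstituted piperidin-1-yl would behave at this carbon remains open.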